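Swapping the aryl group on the ring nitrogen

The source may report more compounds than this note shows. Statements on the series, on what has been measured and on what is new or still open speak of the compounds shown alone.

In a functional assay on DU-145 cells (Homo sapiens) for cytotoxicity, read by MTT assay, with a stated time of 48 h (a higher number here means a weaker inhibitor, a lower number a stronger inhibitor), compound 1 `CCOC(=O)c1c(-c2c(Cl)c3ccccc3oc2=O)nn(-c2ccccc2)c1C(=O)OCC` gives 48000 nM, and compound 2 `CCOC(=O)c1c(-c2c(Cl)c3ccccc3oc2=O)nn(-c2cccc(C)c2)c1C(=O)OCC` gives 32000 nM. The step of a 1.5-fold lower number from compound 1 to compound 2 (0.18 log units; within the scatter) shows that a methyl on the phenyl group changes little. Compound 2 stands at one end of the two numbers, with compound 1 within the scatter of it, so no order between them can be claimed. Compound 3 `CCOC(=O)c1c(-c2c(Cl)c3ccccc3oc2=O)nn(-c2ccc(OC)cc2)c1C(=O)OCC` differs from compound 2 by 4-methoxyphenyl in place of 3-methylphenyl on an aromatic nitrogen. Among the compounds with values here, no measured step covers this exchange; the only related one, a 1.5-fold lower number from compound 1 to compound 2 (0.18 log units; within the scatter), bears on the same phenyl group and was small. Compound 3 is therefore expected to show a 1.1-fold higher number from compound 2 to compound 3 (0.04 log units; within the scatter), no step beyond the scatter in this assay. The estimate for compound 3 is 35000 nM, with a range from 15000 nM to 80000 nM.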

Compound 3, half-maximal inhibitory concentration: 25000 nM
Compound 3: the middle estimate sits 1.4-fold (0.15 log units) above what was measured; measured number inside the range.
By their numbers in this assay, from the lowest: compounds 3, 2 and 1 (each within the scatter of the next).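

At the aryl group on the ring nitrogen of the shared core, 4-methoxyphenyl in place of 3-methylphenyl brings in a hydrogen-bond acceptor, and this assay shows a 1.3-fold lower number from compound 2 to compound 3 (0.11 log units; within the scatter). Compared directly with the plain phenyl group, the 4-methoxyphenyl group gives a 1.9-fold lower number from compound 1 to compound 3 (0.28 log units; within the scatter). A second kind of substituent on this phenyl group, at a different ring position from the methyl, thus also stays within the scatter, and no evidence at hand bears on this result.

Going by these compounds, it remains open whether an amine or a carboxylic acid on this phenyl group would give a step beyond the scatter. On these data alone, it is equally open whether a longer chain on the ring nitrogen, in place of the aryl group, would do so.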